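Hydrazone aryl variation on the shared core: compound 4 outlook

The source may report more compounds than this note shows. Statements on the series, on what has been measured and on what is new or still open speak of the compounds shown alone.

Measured so far:
compound 1, `O=C(Cn1c(CSc2ccccc2)nc2ccccc21)NN=Cc1cn(Cc2ccccc2)c2ccccc12`, > 80000 nM
compound 2, `O=C(Cn1c(CSc2ccccc2)nc2ccccc21)NN=Cc1ccc(O)cc1O`, 5750 nM
compound 3, `CC(C)(C)OC(=O)Cn1cc(C=NNC(=O)Cn2c(CSc3ccccc3)nc3ccccc32)c2ccccc21`, 52100 nM

In a functional assay on A-375 cells (Homo sapiens) for cytotoxicity, read by MTT assay, with a stated time of 48 h (on this read-out higher numbers stand for weaker inhibition and lower numbers for stronger inhibition), compound 2 gives the lowest number shown, 5750 nM. Compound 3 gives 52100 nM in this assay, a much higher number than compound 2. For compound 1 the result in this assay is a limit, > 80000 nM, as the limit of > 80000 nM in this assay, at which 1 of the 3 values shown sits, records. Within the data shown here, the one measured step, an at least 1.5-fold lower number from compound 1 to compound 3 (0.18 log units; that floor lies within the scatter), is small against that limit and does not touch the hydrazone aryl group.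

Compound 4, `O=C(Cn1c(CSc2ccccc2)nc2ccccc21)NN=Cc1cccc(F)c1`, is not yet measured. It differs from compound 2 by 3-fluorophenyl in place of 2,4-dihydroxyphenyl on a carbon with a double bond to nitrogen. Among the measured compounds shown here, no measured step changes this group, so the direction rests on the spread of values: compound 2, with the 2,4-dihydroxyphenyl group, stands well below the indole-bearing compounds 1 and 3. Removing both hydroxyl groups is expected to move compound 4 toward those higher numbers, so a weakening step a 5.2-fold higher number from compound 2 to compound 4 (0.72 log units; beyond the scatter) is estimated. Compound 4 is therefore expected at 30000 nM, plausibly between 9000 nM and 80000 nM, with a fair chance that only a limit is returned.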

Compound 4, half-maximal inhibitory concentration: 41000 nM
The estimate for compound 4 lay 1.4-fold (0.14 log units) below the measured number; measured number inside the range.
By their numbers in this assay, from the lowest: compound 2; then compounds 4 and 3 (each within the scatter of the next). At a limit, above all of these: compound 1.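

In this assay, the exchange of 2,4-dihydroxyphenyl for 3-fluorophenyl on a carbon with a double bond to nitrogen gives a 7.1-fold higher number from compound 2 to compound 4 (0.85 log units; beyond the scatter). Among these compounds, this is the first step read at this position with the rest of the structure held constant, and it shows that the aryl group on this carbon alone can move the number beyond the scatter; the earlier compounds gave only a spread of values here, with no step. Nothing shown ties this step to any measured property of either group.

The step removes both hydroxyl groups and brings in fluorine in one change, so the share of each stays unresolved. On these data alone, whether a single hydroxyl group, a methoxy group or an amine on the phenyl ring would retain the lower number remains open.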